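From phenyl to 2-phenylethenyl on the shared core

The compounds below may be only part of what the source reports. "The series", "measured", "known", "first", "only" and "open" are said of these compounds alone.

In a functional assay on HL-60 cells (Homo sapiens) for antiproliferative activity, with a stated time of 72 h (on this read-out higher numbers stand for weaker inhibition and lower numbers for stronger inhibition), compound 1 (`CCCC#Cc1cc([C@@H]2O[C@H](CO)[C@@H](O)[C@H]2O)n2ncnc(N)c12`) gives 200 nM. Compound 2 (`Nc1ncnn2c([C@@H]3O[C@H](CO)[C@@H](O)[C@H]3O)cc(C#Cc3cccs3)c12`) reads > 100000 nM, which is a limit and not a number. Compound 3 (`Nc1ncnn2c([C@@H]3O[C@H](CO)[C@@H](O)[C@H]3O)cc(-c3ccccc3)c12`) reads > 100000 nM, which is also a limit. Within the data shown here, compound 3 therefore stands at the limit of > 100000 nM in this assay, at which 2 of the 3 values shown sit, and compound 2 is the only other compound there.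

Compound 4 (`Nc1ncnn2c([C@@H]3O[C@H](CO)[C@@H](O)[C@H]3O)cc(/C=C/c3ccccc3)c12`) carries 2-phenylethenyl in place of the phenyl of compound 3 on an aromatic carbon (2-phenylethenyl in place of phenyl on an aromatic carbon). Among the measured compounds shown here, two measured steps bear on this change, and both are large: an at least 500-fold higher number from compound 1 to compound 3 (2.69 log units; beyond the scatter) and an at least 500-fold higher number from compound 1 to compound 2 (2.69 log units; beyond the scatter). In each, a group ending in an aromatic ring replaces the group of compound 1, and the result falls at the limit. The step that the two limits leave unreadable from compound 2 to compound 3 adds no size. Compound 4 also ends in an aromatic ring, and among these compounds no group of that kind has yet given a readable number. In this assay no step beyond the scatter is therefore expected, and another limit is the likeliest report. The expected change is a number no higher from compound 3 to compound 4 (the limit leaves the size open). For compound 4 the estimate is 100000 nM, with an expected range from 15000 nM to 200000 nM.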

Compound 4, half-maximal inhibitory concentration: 2000 nM
For compound 4 the middle estimate is 50-fold (1.70 log units) above the measured one; the measured number lies below the stated range.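

In this assay, a group ending in an aromatic ring on this aromatic carbon can give a readable number, and the change to 2-phenylethenyl brings an at least 50-fold lower number from compound 3 to compound 4 (1.69 log units; beyond the scatter) and, against the thiophene-bearing group, an at least 50-fold lower number from compound 2 to compound 4 (1.69 log units; beyond the scatter). Compound 2 and compound 3 remain at a limit of the assay, and compound 4 does not join them: the limit of > 100000 nM in this assay, at which 2 of the 4 values shown sit. Even so, 2-phenylethenyl does not match the open-chain pent-1-yn-1-yl, as a 10-fold higher number from compound 1 to compound 4 (1.00 log units; beyond the scatter) shows, so the aromatic ring at the end of this group is compatible with activity here, though in compound 4 it falls short of compound 1.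

On these data alone, it remains open how 2-phenylethyl or 2-phenylethynyl on this carbon would read, and either would help separate the part played by the double bond from that of the link as such. As far as these compounds go, it is also open whether a methoxy group or an amine on the phenyl ring of compound 4, or a saturated chain such as pentyl in place of pent-1-yn-1-yl, would bring the number closer to that of compound 1.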